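The source may hold more compounds than are shown below. What is called first, only, known or untested is meant among the compounds shown, and "the series" means these compounds.

Compound 1 `Cc1ccc(Oc2ccc(/C=N/NC(=S)Nc3ccccc3)cc2)cc1`, compound 2 `Cc1ccc(Oc2ccc(/C=N/NC(=S)Nc3ccc(Cl)cc3)cc2)cc1` and compound 3 `Cc1ccc(Oc2ccc(/C=N/NC(=S)Nc3ccc(Br)cc3)cc2)cc1` share one core and differ only in what sits on the outer aromatic ring. In a physicochemical assay for lipophilicity, in phosphate buffer, measured as octanol-water partition, with a stated time of 24 h (on this read-out higher numbers stand for higher lipophilicity and lower numbers for lower lipophilicity), compound 1 gives 5.39, compound 2 gives 5.97 and compound 3 gives 6.17. Compound 3 stands clearly beyond compound 1, a step of a number 0.78 log units higher from compound 1 to compound 3 (beyond the scatter), while compound 2 lies within the scatter of it, a step of a number 0.20 log units higher from compound 2 to compound 3 (within the scatter). Compound 4 `S=C(N/N=C/c1ccc(Oc2ccc(Cl)cc2)cc1)Nc1ccc(Br)cc1` keeps the bromo of compound 3 and alters the other ring: chloro in place of methyl on an aromatic carbon. For the measured compounds named here, no measured step swaps chloro for methyl directly. What the data do show is that chloro in place of hydrogen gave a number 0.58 log units higher from compound 1 to compound 2 (beyond the scatter) and bromo in place of hydrogen gave a number 0.78 log units higher from compound 1 to compound 3 (beyond the scatter), with the two halogens within the scatter of each other. Since a methyl already occupies the position in compound 3, trading it for chloro is expected to move this assay only a little, a number 0.13 log units higher from compound 3 to compound 4 (within the scatter). Compound 4 is thus estimated at 6.3, between 5.9 and 6.7.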

Compound 4, partition coefficient: 6.24
Beside the measured number, compound 4's estimate is 0.06 log units above it; measured number inside the range.
By their numbers in this assay, from the lowest: compound 1; then compounds 2, 3 and 4 (each within the scatter of the next).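

In this assay, the change from 4-methylphenoxy to 4-chlorophenoxy gives a number 0.07 log units higher from compound 3 to compound 4 (within the scatter), so this one swap, on an aromatic carbon para to a large group, leaves the two compounds indistinguishable. For the compounds shown here, the earlier steps showed only that chloro or bromo in place of hydrogen on the outer ring gave a clear rise and that the two halogens could not be told apart; this is the first direct comparison of methyl with chloro, and it concerns a different position. No measurement here explains why the two groups read alike.

The compounds shown carry only methyl or chloro at this position, so how an amine, a carboxylic acid or a longer chain would read there remains open. Also open, going by these compounds, is whether the methyl-to-chloro swap would read the same without the bromo on the outer ring.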